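The compounds below may be only part of what the source reports. "The series", "measured", "known", "first", "only" and "open" are said of these compounds alone.

In a functional assay on the whole organism (strain BALB/c) with Mus musculus as the target, in the writhing test, with a stated time of 1 h, at a dose of 200 mg/kg by the oral route (on this read-out higher numbers stand for a stronger effect at the one dose given and lower numbers for a weaker effect), compound 1 `COc1ccc(Cc2n[nH]c(=S)n2N)cc1` gives 46.7%. Compound 2 `COc1ccc(Cc2nnc3n2N=C(c2ccc(Cl)cc2)CS3)cc1` gives 39% in this assay, a number that lies within the scatter of the value of compound 1, so the two stand together on this read-out. Compound 3 `COc1ccc(Cc2nnc3n2N=C(c2ccc(F)cc2)CS3)cc1` differs from compound 2 by fluoro in place of chloro on an aromatic carbon. Among the measured compounds shown here, no measured pair shows this change, so the numbers give no size for it. In this assay the step of a number 2 percentage points lower from compound 2 to compound 3 (within the scatter) is expected to stay within the scatter. Compound 3 is therefore estimated to give 37% in this assay, with a range from 22% to 52%.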

Compound 3, a percentage reported as inhibition, in the whole organism at one dose (the size of the read-out at that dose, not a potency): 31.5%
Compound 3: middle estimate off by 5.5 percentage points, on the high side; low and high end bracket the measured number.
By their numbers in this assay, from the lowest: compounds 3, 2 and 1 (each within the scatter of the next, the first and the last beyond it).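

Replacing chloro with fluoro on the aromatic carbon para to a large group gives in this assay the first measured size for this change, a number 7.5 percentage points lower from compound 2 to compound 3 (within the scatter) and so the two halogens are not told apart on this read-out at this place. Nothing available bears on why the two compounds compare this way.

Only these two halogens are shown at this place, so it remains open how a methyl, an amine or a nitrile there would compare with compound 2. As far as these compounds go, whether the same change behaves alike on another core also remains open.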